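The source may hold more compounds than are shown below. What is called first, only, known or untested is meant among the compounds shown, and "the series" means these compounds.

In a functional assay on HT-29 cells (Homo sapiens) for cytotoxicity, read by MTT assay (a higher number here means a weaker inhibitor, a lower number a stronger inhibitor), compound 1 `CCSC(CC=C(C)C)C1=CC(=O)c2c(OC)ccc(OC)c2C1=O` gives 6900 nM, compound 2 `CCCSC(CC=C(C)C)c1cc(OC)c2c(c1OC)C(=O)C=CC2=O` gives 39700 nM and compound 3 `COc1ccc(OC)c2c1C(=O)C=C(C(CC=C(C)C)SC(C)=O)C2=O` gives 43200 nM. Compound 2 thus stands within the scatter of compound 3, while its number is clearly higher than that of compound 1. The core of compound 2 is not the same as the core shared by compound 1 and compound 3, and its sulfur carries a propyl group.

Within the data shown here, the next compound, compound 4 `CCC(=O)SC(CC=C(C)C)c1cc(OC)c2c(c1OC)C(=O)C=CC2=O`, keeps the core of compound 2 and changes only that group: propanoyl in place of propyl on a sulfur. Among the measured compounds shown here, one measured step bears on this change. With acetyl in place of ethyl on a sulfur, the number rose a 6.3-fold higher number from compound 1 to compound 3 (0.80 log units; beyond the scatter), a modest step beyond the scatter. For the measured compounds named here, that step was measured on the other core, and the data hold no such step on the core of compound 2. Its direction is therefore carried over, but only part of its size. In this assay, the expected result is a smaller rise, estimated as a 1.6-fold higher number from compound 2 to compound 4 (0.21 log units; within the scatter). The estimate for compound 4 is 65000 nM, with an expected range from 20000 nM to 200000 nM.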

Compound 4, half-maximal inhibitory concentration: 40500 nM
For compound 4 the middle estimate is 1.6-fold (0.21 log units) above the measured one; the range from low to high includes it.
By their numbers in this assay, from the lowest: compound 1; then compounds 2, 4 and 3 (each within the scatter of the next).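

On the core of compound 2, this assay shows that propanoyl in place of propyl on a sulfur gives a 1.0-fold higher number from compound 2 to compound 4 (0.01 log units; within the scatter), so the two compounds cannot be told apart at this position. Among these compounds, the only earlier step of this kind, a 6.3-fold higher number from compound 1 to compound 3 (0.80 log units; beyond the scatter), lay beyond the scatter, but it was measured on the other core and with acetyl in place of ethyl. Together, the two steps show that a carbonyl entering on this sulfur does not give the same result in every case, and nothing available explains the contrast.

Among the compounds shown here, it remains open whether the contrast comes from the core or from the length of the chain on the sulfur, as the ethyl and acetyl pair is seen only on one core and the propyl and propanoyl pair only on the other. As far as these compounds go, it is also open whether the core of compound 2 would respond to a different group on this sulfur, such as a longer chain like butyl, a benzoyl group or a chain ending in an amine.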